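Replacing pyridin-4-yl with 3,4-dichlorophenyl in compound 4

The source may hold more compounds than are shown below. What is called first, only, known or untested is meant among the compounds shown, and "the series" means these compounds.

Measured in a functional assay on CHO cells with adenosine receptor A1 (Homo sapiens) as the target, read by cAMP accumulation and immunoassay, with a stated time of 6 min, tested at 1 uM; a lower number here means a stronger effect, a higher number a weaker effect of the compound at the concentration tested:
Compound 1 `Nc1scc(CN2CCN(c3ccncc3)CC2)c1C(=O)c1ccc(Cl)cc1` — -8.3%
Compound 2 `Nc1scc(CN2CCN(c3cccc(F)c3)CC2)c1C(=O)c1ccc(Cl)cc1` — -86%
Compound 3 `Nc1scc(CN2CCN(c3cc(F)ccc3F)CC2)c1C(=O)c1ccc(Cl)cc1` — -59%

Compound 1 stands highest of the three numbers; compound 3 lies nearest and compound 2 furthest, both beyond the scatter. Compound 4 `Nc1scc(CN2CCN(c3ccc(Cl)c(Cl)c3)CC2)c1C(=O)c1ccc(Cl)cc1` has not yet been measured. It differs from compound 1 as follows: 3,4-dichlorophenyl in place of pyridin-4-yl on an amine nitrogen in a ring. Among the compounds with values here, two measured steps bear on this exchange of the ring on the amine nitrogen, a number 77.7 percentage points lower from compound 1 to compound 2 (beyond the scatter) and a number 50.7 percentage points lower from compound 1 to compound 3 (beyond the scatter), both large and both lower. The step of a number 27 percentage points higher from compound 2 to compound 3 (beyond the scatter) shows that the halogen pattern on the entering ring moves the number only modestly. A large step lower is therefore expected, a number 56.7 percentage points lower from compound 1 to compound 4 (beyond the scatter). Compound 4 is estimated at -65%, between -95% and -30%.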

Compound 4, a percentage reported as activity, at one concentration (the size of the read-out at that concentration, not a potency): -60%
Beside the measured number, compound 4's estimate is 5 percentage points below it; the range from low to high includes it.
By their numbers in this assay, from the lowest: compound 2; then compounds 4 and 3 (each within the scatter of the next); then compound 1.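

In this assay the large shift away from pyridin-4-yl on the amine nitrogen in the ring also holds with chlorine on the entering ring, with a number 51.7 percentage points lower from compound 1 to compound 4 (beyond the scatter). The two rings carrying a pair of halogens cannot be told apart, with a number 1 percentage points lower from compound 3 to compound 4 (within the scatter), while 3-fluorophenyl remains separate, with a number 26 percentage points higher from compound 2 to compound 4 (beyond the scatter). Nothing measured here explains these differences.

Going by these compounds, it remains open whether a methoxy group or a nitrile on the entering phenyl ring would give a number as low. The same holds for a pyridin-3-yl ring at this position.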